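This account rests on a few compounds, and the source may have more. Where it says the series, first, only, none or still open, it means among the compounds named here.

Compound 1, `C[C@]1(O)C[C@@](c2cccc(C(F)(F)F)c2)([C@H](O)c2ccccn2)C1`: 150 mL/min/kg
Compound 2, `O[C@H](c1ccccn1)C1(c2ccc(Cl)c(Cl)c2)CC(F)(F)C1`: 250 mL/min/kg
Compound 3, `C[C@]1(O)C[C@@](c2ccc(OC(F)(F)F)cc2)([C@H](O)c2ccccn2)C1`: 66.7 mL/min/kg

These three compounds were tested in an ADME assay on liver for metabolic stability, with Liver microsome (Homo sapiens) as the target, read by LC-MS, using microsomes, with a stated time of 5 h; on this read-out higher numbers stand for fast clearance and lower numbers for slow clearance. Among them compound 1 stands second highest, giving 150 mL/min/kg. Compound 2 gives 250 mL/min/kg, a number that sits within the usual scatter of repeated measurements around compound 1, so the two cannot be told apart. Compound 3 gives 66.7 mL/min/kg, which lies beyond the scatter on the lower side of compound 1 and so points to slower clearance for compound 3.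

Compound 4, `C[C@]1(O)C[C@](c2cccc(C(F)(F)F)c2)([C@H](O)c2ccccn2)C1`, has not yet been measured in this assay. It differs from compound 1 as follows: the two compounds have the same atoms and bonds and differ only in configuration as drawn: 2 of 3 stereo elements differ; a stereocentre at a saturated ring carbon is drawn R in compound 1 and S in compound 4; a stereocentre at a saturated ring carbon is drawn s in compound 1 and r in compound 4. Both compounds are thus built from the same atoms and bonds; only the spatial arrangement at two saturated ring carbons is reversed. None of the three measured compounds forms such a pair with another, so nothing shown here tells how large a step of this kind tends to be. With no comparison to lean on, the step from compound 1 to compound 4 is expected to be a 1.2-fold lower number from compound 1 to compound 4 (0.06 log units; within the scatter), staying within the scatter. Compound 4 is therefore expected to give about 130 mL/min/kg in this assay, within a range from 60 mL/min/kg to 280 mL/min/kg.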

Compound 4, clearance: 33.3 mL/min/kg
Estimate against measurement, compound 4: 3.9-fold (0.59 log units) above, outside the stated range (below it).
By their numbers in this assay, from the lowest: compounds 4 and 3 (each within the scatter of the next); then compounds 1 and 2 (each within the scatter of the next).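

In this assay, the reversal of the two saturated ring carbons gives a 4.5-fold lower number from compound 1 to compound 4 (0.65 log units; beyond the scatter) and so moves clearance by more than the usual scatter of repeated measurements. The earlier compounds shown here could not show this, since none of them formed a pair of this kind, and they left open whether spatial arrangement at these ring carbons matters at all for this read-out. Here the change in clearance can be traced to the arrangement itself rather than to any added or removed group, because nothing else separates the two structures: the fact that compounds 1 and 4 differ only in the configuration as drawn.

This single pair leaves open whether the same reversal would lower clearance with a different group on the aromatic ring, such as the trifluoromethoxy group of compound 3, and whether one of the two reversed ring carbons accounts for the step or both are needed. It also leaves open how clearance would respond if an amine or a carboxylic acid took the place of the ring hydroxyl in either spatial arrangement.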